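Swapping difluorophenyl for phenyl on the sulfonyl group

This account rests on a few compounds, and the source may have more. Where it says the series, first, only, none or still open, it means among the compounds named here.

Three compounds have been measured in an assay on isolated protein for displacement of a labelled ligand from metabotropic glutamate receptor 5 (Homo sapiens), with a stated time of 60 min, tested at 1 uM; a higher number here means more inhibition at the concentration tested (going by the name of the read-out), a lower number less inhibition:
compound 1, `CC1CCN(c2c(S(=O)(=O)c3ccccc3)cnc3cc(Cl)ccc23)CC1`, gives 93%
compound 2, `CC1CCN(c2c(S(=O)(=O)c3ccc(F)c(F)c3)cnc3cc(Cl)ccc23)CC1`, gives 90%
compound 3, `CC1CCN(c2c(S(=O)(=O)c3ccc(F)c(F)c3)cnc3cc(F)ccc23)CC1`, gives 94%

Compound 4, `CC1CCN(c2c(S(=O)(=O)c3ccccc3)cnc3cc(F)ccc23)CC1`, has not yet been tested in this assay. It differs from compound 3 in a single place: phenyl in place of 3,4-difluorophenyl on a sulfonyl sulfur. The same change has already been made once among these compounds, from compound 2 to compound 1, where it reads phenyl in place of 3,4-difluorophenyl on a sulfonyl sulfur and gave a number 3 percentage points higher from compound 2 to compound 1 (within the scatter). Compounds 3 and 4 share a core that differs from the core of compounds 2 and 1 by fluoro in place of chloro on an aromatic carbon, and that change on its own gave a number 4 percentage points higher from compound 2 to compound 3 (within the scatter). All three measured numbers lie within the scatter of one another, so neither change has so far produced a visible effect. The step from compound 3 to compound 4 is therefore expected to be small, about a number 1 percentage points higher from compound 3 to compound 4 (within the scatter), resting on the earlier step of a number 3 percentage points higher from compound 2 to compound 1 (within the scatter) and on compound 3 already giving 94%. Compound 4 is expected to give about 95%, with a likely range from 88% to 99%.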

Compound 4, a percentage reported as inhibition, at one concentration (the size of the read-out at that concentration, not a potency): 87%
Estimate against measurement, compound 4: 8 percentage points above; the whole stated range lies above it.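

In this assay, the phenyl swap on the fluoro core gives a number 7 percentage points lower from compound 3 to compound 4 (within the scatter), and changing chloro to fluoro on the phenyl compounds gives a number 6 percentage points lower from compound 1 to compound 4 (within the scatter). Set beside its earlier counterpart, the phenyl swap shows no real difference between the two cores: the same change on two cores in this assay, a number 3 percentage points higher (within the scatter) from compound 2 to compound 1 and a number 7 percentage points lower (within the scatter) from compound 3 to compound 4, 10 percentage points apart, within the scatter of two such steps. Among these compounds, the fluoro-for-chloro change reads the same way, but this does not show that either change has a real effect on any core, nor that the two changes are proven to behave identically on both, only that these four compounds cannot tell such differences apart: the same change on two cores in this assay, a number 4 percentage points higher (within the scatter) from compound 2 to compound 3 and a number 6 percentage points lower (within the scatter) from compound 1 to compound 4, 10 percentage points apart, within the scatter of two such steps.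

The compounds shown leave open what happens when the aromatic ring on the sulfonyl sulfur gives way to something quite different, such as a methyl group or an amine, which might produce a step large enough to read. They also leave open how the four compounds would rank by potency, since each number here is a reading at a single concentration.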